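This account rests on a few compounds, and the source may have more. Where it says the series, first, only, none or still open, it means among the compounds named here.

Compound 1 `Nc1nc(O)nc2c1nc(O)n2Cc1ccccc1` is the reference point of this pair. Within the data shown here, in a functional assay (spleen, spleen) for activation, with Mus musculus as the target (a lower number here means that less compound is needed, a higher number that more compound is needed for the effect), compound 1 gives 0.1 uM, the lowest of the two numbers measured so far. Among the measured compounds shown here, compound 2 `CCNc1nc(N)c2nc(O)n(Cc3ccccc3)c2n1` is the only other measured member; in this assay compound 2 gives 1 uM, and the single measured step, a 10-fold higher number from compound 1 to compound 2 (1.00 log units; beyond the scatter), is a modest weakening from ethylamino in place of hydroxy on an aromatic carbon. Compound 3 `Nc1nc(S)nc2c1nc(O)n2Cc1ccccc1` is not yet measured. It differs from compound 1 as follows: sulfanyl in place of hydroxy on an aromatic carbon. For the measured compounds named here, the change sits at the same aromatic carbon that was altered in going to compound 2, but no measured step covers a sulfanyl there, so the only bearing comes from compound 2, whose step a 10-fold higher number from compound 1 to compound 2 (1.00 log units; beyond the scatter) shows that replacing the hydroxy at this position costs potency. A smaller loss than that is expected for compound 3, a 3.0-fold higher number from compound 1 to compound 3 (0.48 log units; beyond the scatter). The estimate for compound 3 in this assay is 0.3 uM, expected within 0.1 uM to 1 uM.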

Compound 3, minimum effective concentration: 10 uM
Compound 3: the middle estimate sits 33-fold (1.52 log units) below what was measured; measured number above the stated range.
By their numbers in this assay, from the lowest: compound 1; then compound 2; then compound 3.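

Working notes: in this assay, sulfanyl in place of hydroxy on the aromatic carbon between two ring nitrogen atoms gives a 100-fold higher number from compound 1 to compound 3 (2.00 log units; beyond the scatter), although the leaving and entering groups match in heavy-atom, hydrogen-bond donor and hydrogen-bond acceptor counts, so those counts alone do not account for the result at this position. The exchange of oxygen for sulfur also costs more than the ethylamino replacement, with a 10-fold higher number from compound 2 to compound 3 (1.00 log units; beyond the scatter), which places the three groups at this position in the order hydroxy, ethylamino, sulfanyl by rising number. No measured data bear on the reason for the large loss with sulfanyl.

Open, going by these compounds, is where an amino or methoxy group would fall in this order. Also open, on these data alone, is whether a methylsulfanyl group would give back any of the loss seen with sulfanyl.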